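The compounds below may be only part of what the source reports. "The series", "measured", "known", "first", "only" and "open" are said of these compounds alone.

Measured so far:
Compound 1 `O=[N+]([O-])c1cc(S(=O)(=O)Nc2ccc(-c3nc4ccccc4o3)cc2)ccc1Cl`: > 63000 nM
Compound 2 `O=S(=O)(Nc1ccc(-c2nc3ccccc3o2)cc1)c1ccc(C(F)(F)F)cc1`: > 63000 nM

In an assay on isolated protein for inhibition of malate dehydrogenase, mitochondrial (Sus scrofa), with stated times of 45 min and 30 min (on this read-out higher numbers stand for weaker inhibition and lower numbers for stronger inhibition), compound 1 gives > 63000 nM, which is a limit of the assay and not a number. In this assay compound 2 gives > 63000 nM, again a limit rather than a number. Among the measured compounds shown here, compound 2 thus stands at the limit of the assay, and so does the only other value shown (the limit of > 63000 nM in this assay, at which 2 of the 2 values shown sit). Compound 3 `O=S(=O)(Nc1ccc(-c2nc3ccccc3o2)cc1)c1ccc(Cl)cc1` differs from compound 2 in one exchange, (chloro in place of trifluoromethyl on an aromatic carbon), chloro in place of trifluoromethyl on an aromatic carbon. For the measured compounds named here, no step between measured compounds is available, so the size of this change cannot be read from the data. Compound 2 sits at the limit > 63000 nM. Compound 3 is expected to remain near that limit, the expected step from compound 2 to compound 3 being a step that the limit leaves unreadable from compound 2 to compound 3, with a limit again the most probable outcome. Compound 3 is estimated at 80000 nM, between 30000 nM and 250000 nM.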

Compound 3, half-maximal inhibitory concentration: > 63000 nM
Compound 3: no number, only a limit; the forecaster's own chance of this, stated with the estimate: 85%; the middle value is on the limit's open side.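

The steps from compound 1 and from compound 2 to compound 3 cannot be read, as this assay gives only a limit for each of the three: the limit of > 63000 nM in this assay, at which 3 of the 3 values shown sit. The compounds shown leave open how the chloro, trifluoromethyl and nitro compounds compare, and whether any change to the shared core would give a measurable value.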